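Two hydroxy positions on the aromatic ring

The source may hold more compounds than are shown below. What is called first, only, known or untested is meant among the compounds shown, and "the series" means these compounds.

Measured in a functional assay on UACC-62 cells (Homo sapiens) for inhibition, read by sulforhodamine B assay, with a stated time of 48 h; a lower number here means a stronger inhibitor of growth, a higher number a weaker inhibitor of growth:
compound 1, `CC1(/C=C/c2ccccc2)C=CC(=O)O1`: 97200 nM
compound 2, `CC1(/C=C/c2ccccc2O)C=CC(=O)O1`: 92500 nM

Compound 1 stands highest of the two numbers in this assay, with compound 2 nearest at a gap within the scatter. Compound 3, `CC1(/C=C/c2ccc(O)cc2)C=CC(=O)O1`, has not yet been measured. It differs from compound 1 by hydroxy in place of hydrogen on an aromatic carbon. For the measured compounds named here, one measured step bears on this change: hydroxy in place of hydrogen on an aromatic carbon of the same ring gave a 1.1-fold lower number from compound 1 to compound 2 (0.02 log units; within the scatter), a change within the scatter. Going by the values given here, with only that step to go on, no movement beyond the scatter is expected from this change in this assay, and the estimate for compound 3 rests on compound 1 at 97200 nM together with compound 2 at 92500 nM. Compound 3 is therefore expected near 90000 nM, with a range from 40000 nM to 200000 nM, which amounts to an expected step of a 1.1-fold lower number from compound 1 to compound 3 (0.03 log units; within the scatter).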

Compound 3, concentration for total growth inhibition: 55300 nM
Compound 3: the middle estimate sits 1.6-fold (0.21 log units) above what was measured; low and high end bracket the measured number.
By their numbers in this assay, from the lowest: compounds 3, 2 and 1 (each within the scatter of the next).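

With hydroxy in place of hydrogen on an aromatic carbon, now para to a group of 9 heavy atoms, this assay gives a 1.8-fold lower number from compound 1 to compound 3 (0.24 log units; within the scatter). This adds a second ring position to the one seen with compound 2, and at neither position does the step from compound 1 leave the scatter, so the change has not yet been shown to alter growth inhibition at either place. Nothing available explains the result at this position, and the data give no reason for it.

On these data alone, whether a methoxy group, an amine or a carboxylic acid at this same ring position would move the number beyond the scatter remains open. Also open, as far as these compounds go, is whether hydroxy groups on both ring positions together would do so.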